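The compounds below may be only part of what the source reports. "The series", "measured", "known", "first", "only" and "open" are said of these compounds alone.

Measured compounds:
- compound 1 `Oc1cccc(-c2cc(-c3cccc(Cl)c3)nc(-c3ccco3)c2)c1`: 2020 nM
- compound 2 `Oc1cccc(-c2cc(-c3cccs3)nc(-c3ccccc3Cl)c2)c1`: 1700 nM
- compound 3 `Oc1cccc(-c2cc(-c3ccccn3)nc(-c3ccccc3Cl)c2)c1`: "not determined" (no result reported)

In a functional assay on DU-145 cells (Homo sapiens) for cytotoxicity, read by CCK-8 assay and cell counting, with a stated time of 2 days (on this read-out lower numbers stand for stronger inhibition and higher numbers for weaker inhibition), compound 1 gives 2020 nM. In this assay compound 2 gives 1700 nM, and the two numbers sit within the usual scatter of each other, so nothing separates them. Compound 3 stands apart from both: in this assay compound 3 gives "not determined" (no result reported), so its place among the measured compounds is open.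

Compound 4 `Oc1cccc(-c2cc(-c3ccco3)nc(-c3ccccc3Cl)c2)c1` is compound 3 with one change, (furan-2-yl in place of pyridin-2-yl on an aromatic carbon). Among the measured compounds shown here, since compound 3 carries no value, the step from compound 3 to compound 4 in this assay cannot be sized from the data, and no other pair in the set shows this same exchange. What remains as a guide is that compound 4 shares its furan-2-yl group with compound 1 and its 2-chlorophenyl group with compound 2, both of which were measured. On that basis compound 4 is expected to land near those two, at an estimated 1800 nM with a range from 600 nM to 6000 nM.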

Compound 4, half-maximal inhibitory concentration: 1630 nM
Estimate against measurement, compound 4: 1.1-fold (0.04 log units) above; low and high end bracket the measured number.
By their numbers in this assay, from the lowest: compounds 4, 2 and 1 (each within the scatter of the next).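

In this assay, furan-2-yl in place of thiophen-2-yl on the aromatic carbon next to the ring nitrogen gives a 1.0-fold lower number from compound 2 to compound 4 (0.02 log units; within the scatter), so among the compounds with a 2-chlorophenyl group, these two five-membered aromatic rings are not told apart. With furan-2-yl held fixed, 2-chlorophenyl in place of 3-chlorophenyl gives a 1.2-fold lower number from compound 1 to compound 4 (0.09 log units; within the scatter), which also stays within the scatter, so this exchange does not separate the compounds either. Nothing on hand offers an explanation for these results.

As far as these compounds go, the step from compound 3 to compound 4 cannot be read, so it remains open whether pyridin-2-yl and furan-2-yl differ at this position. Also open, from the compounds shown here alone, is whether an amine or a carboxylic acid on this aromatic carbon would shift the number beyond the scatter.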